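Vero cytotoxicity: benzylurea in place of propylurea

The compounds below may be only part of what the source reports. "The series", "measured", "known", "first", "only" and "open" are said of these compounds alone.

Compound 3 `CCCNC(=O)Nc1cc2nc(C3CCCCC3)[nH]c2cc1N(CC)CC` carries a propylamino group on the carbonyl carbon of the shared core. In an ADME assay on Vero cells (Chlorocebus sabaeus) for cytotoxicity, read by resazurin assay, with a stated time of 3 days (on this read-out lower numbers stand for stronger inhibition and higher numbers for weaker inhibition), compound 3 gives > 100 ug/mL, which is a limit of the assay and not a number. Compound 1 `CCN(CC)c1cc2[nH]c(C3CCCCC3)nc2cc1NC(=O)c1ccc(OC(F)(F)F)cc1` likewise gives only a limit in this assay, > 100 ug/mL. Compound 2 `CCCC(C)OC(=O)Nc1cc2nc(C3CCCCC3)[nH]c2cc1N(CC)CC` also stops at a limit in this assay, > 100 ug/mL. All three values sit at the limit of > 100 ug/mL in this assay, at which 3 of the 3 values shown sit. The steps a step that the two limits leave unreadable from compound 1 to compound 2, a step that the two limits leave unreadable from compound 1 to compound 3 and a step that the two limits leave unreadable from compound 2 to compound 3 therefore have no readable size; exchanging the group on the carbonyl carbon among an aryl, an alkoxy and an alkylamino group leaves no visible shift in this assay. Compound 4 `CCN(CC)c1cc2[nH]c(C3CCCCC3)nc2cc1NC(=O)NCc1ccccc1` differs from compound 3 by phenyl in place of ethyl on a saturated chain carbon bound to an amide-type nitrogen. Among the compounds with values here, no measured step covers this particular change; the three measured compounds show only that varied substituents on the carbonyl carbon all remain at the limit. For compound 4 a step of a number no higher from compound 3 to compound 4 (the limit leaves the size open) is expected, meaning no change beyond the scatter. Compound 4 is therefore expected to give about 100 ug/mL in this assay, within 50 ug/mL to 200 ug/mL, most probably again reported as a limit.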

Compound 4, half-maximal inhibitory concentration: > 100 ug/mL
Compound 4: no number, only a limit; the forecaster's own chance of this, stated with the estimate: 85%; the middle value sits exactly at the limit.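

In this assay, within the data shown here, compound 4 gives > 100 ug/mL which is a limit of the assay and not a number, so no step among compound 1, compound 2, compound 3 and compound 4 can be read. The compounds shown leave open whether any group on the carbonyl carbon changes this read-out: the limit of > 100 ug/mL in this assay, at which 4 of the 4 values shown sit.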